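This account rests on a few compounds, and the source may have more. Where it says the series, first, only, none or still open, it means among the compounds named here.

In a functional assay on A549 cells (Homo sapiens) for antiproliferative activity, read by MTT assay, with a stated time of 48 h (on this read-out lower numbers stand for stronger inhibition and higher numbers for weaker inhibition), compound 2 (`C=C(c1cc(OC)c(OC)c(OC)c1)c1ccc(OC)cc1NC(=O)CN`) gives 40 nM as its value, within the usual scatter of compound 1 (`C=C(c1ccc2c(c1)C=CC(C)(C)O2)c1ccc(OC)cc1NC(=O)CN`) at 60 nM on the same read-out, whereas compound 3 (`C=C(c1ccc(OC)cc1NC(=O)CNC)c1ccc(OC)c2c1OC(C)(C)C=C2`) at 150 nM stands higher, beyond the scatter. Compound 4 (`C=C(c1cc(OC)c(OC)c(OC)c1)c1ccc(OC)cc1NC(=O)CN(C)C`) differs from compound 2 in one place, with dimethylamino in place of amino on a saturated chain carbon bound to a carbonyl carbon. Among the compounds with values here, no measured pair isolates this change. Compound 3 also lacks the plain amino group but differs elsewhere too, so its value of 150 nM is only a weak hint toward weaker inhibition. The expected change is modest, an estimated step (a 2.3-fold higher number from compound 2 to compound 4 (0.35 log units; beyond the scatter)) toward a higher number, slightly beyond the scatter. Compound 4 is expected near 90 nM (estimated range 30 nM to 300 nM).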

Compound 4, half-maximal inhibitory concentration: 130 nM
Estimate against measurement, compound 4: 1.4-fold (0.16 log units) below; measured number inside the range.
By their numbers in this assay, from the lowest: compounds 2 and 1 (each within the scatter of the next); then compounds 4 and 3 (each within the scatter of the next).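

In this assay, within the data shown here, dimethylamino in place of amino on a saturated chain carbon bound to a carbonyl carbon gives a 3.3-fold higher number from compound 2 to compound 4 (0.51 log units; beyond the scatter), the first measured pair that isolates this change. Inhibition therefore weakens measurably, though it is not lost. The swap adds two carbons and removes the hydrogen-bond donor, and nothing at hand explains the shift. Still open, as far as these compounds go, is how a ring amine such as morpholine, or a longer chain carrying the amino group, would behave at this place on the core of compound 2.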